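Fluoro in place of tert-butyl: working notes

The source may hold more compounds than are shown below. What is called first, only, known or untested is meant among the compounds shown, and "the series" means these compounds.

- Compound 1 `CCc1ccc(C(=O)/C=C/C(=O)O)cc1`: 27800 nM
- Compound 2 `CCCCc1ccc(C(=O)/C=C/C(=O)O)cc1`: 4780 nM
- Compound 3 `CC(C)(C)c1ccc(C(=O)/C=C/C(=O)O)cc1`: 5100 nM

In a functional assay on HeLa cells (Homo sapiens) for inhibition, read by MTT assay, with a stated time of 72 h (a lower number here means a stronger inhibitor, a higher number a weaker inhibitor), compound 3 gives 5100 nM. Against its closest neighbour the data show a 1.1-fold higher number from compound 2 to compound 3 (0.03 log units; within the scatter), and against the most distant value they show a 5.5-fold lower number from compound 1 to compound 3 (0.74 log units; beyond the scatter). Compound 4 `O=C(O)/C=C/C(=O)c1ccc(F)cc1` carries fluoro in place of tert-butyl on an aromatic carbon. Among the measured compounds shown here, no measured compound carries fluoro, so the nearest guide is compound 1, with ethyl at this carbon, and the steps of a 5.8-fold lower number from compound 1 to compound 2 (0.76 log units; beyond the scatter) and a 5.5-fold lower number from compound 1 to compound 3 (0.74 log units; beyond the scatter). A step of similar size towards a higher number is therefore expected. The expected step is a 5.9-fold higher number from compound 3 to compound 4 (0.77 log units; beyond the scatter). Compound 4 is estimated at 30000 nM, with an expected range of 12000 nM to 70000 nM.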

Compound 4, half-maximal inhibitory concentration: 28400 nM
Compound 4: middle estimate off by 1.1-fold (0.02 log units), on the high side, and the stated range covers the measured number.
By their numbers in this assay, from the lowest: compounds 2 and 3 (each within the scatter of the next); then compounds 1 and 4 (each within the scatter of the next).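

Fluoro returns this position to the higher end of the series: in this assay, replacing tert-butyl gives (a 5.6-fold higher number from compound 3 to compound 4 (0.75 log units; beyond the scatter)) and replacing butyl gives (a 5.9-fold higher number from compound 2 to compound 4 (0.77 log units; beyond the scatter)), while fluoro and ethyl cannot be told apart (a 1.0-fold higher number from compound 1 to compound 4 (0.01 log units; within the scatter)). At this aromatic carbon a single fluorine atom thus reads like ethyl, and only tert-butyl and butyl stand apart, branched or not. Nothing at hand explains this result.

Going by these compounds, whether methoxy or trifluoromethyl at this carbon would fall with fluoro and ethyl or with butyl and tert-butyl stays open. So does the effect of a chain longer than butyl.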